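A methoxyphenyl replaces dichlorophenyl on the aromatic nitrogen

This account rests on a few compounds, and the source may have more. Where it says the series, first, only, none or still open, it means among the compounds named here.

Of the compounds shown here, two have so far been measured in a functional assay on PC-3 cells (Homo sapiens) for antiproliferative activity, read by MTT assay, with a stated time of 48 h; a higher number here means a weaker inhibitor, a lower number a stronger inhibitor. Compound 1 `COc1cc(/C=C/C(C)=O)ccc1OCc1cn(-c2c(F)cccc2F)nn1` gives 24200 nM, and compound 2 `COc1cc(/C=C/C(C)=O)ccc1OCc1cn(-c2c(Cl)cccc2Cl)nn1` gives 3070 nM. For the measured compounds named here, the single recorded step, a 7.9-fold lower number from compound 1 to compound 2 (0.90 log units; beyond the scatter), exchanges 2,6-difluorophenyl for 2,6-dichlorophenyl on the aromatic nitrogen. Going by the values given here, compound 2 thus holds the lowest of the two numbers, with compound 1 its only neighbour. Compound 3 `COc1cc(/C=C/C(C)=O)ccc1OCc1cn(-c2ccccc2OC)nn1` carries the change (2-methoxyphenyl in place of 2,6-dichlorophenyl on an aromatic nitrogen). No measured step bears directly on this: the one known step concerns a swap of halogens, whereas here a 2-methoxyphenyl enters, a group without precedent among these compounds. Its direction cannot be read from the data, so the expectation is a modest move toward a higher number with a wide band around it. The estimate made here amounts to an expected 2.6-fold higher number from compound 2 to compound 3 (0.42 log units; beyond the scatter). For compound 3 in this assay a value of 8000 nM is estimated, with a range from 2000 nM to 30000 nM.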

Compound 3, half-maximal inhibitory concentration: 2050 nM
Estimate against measurement, compound 3: 3.9-fold (0.59 log units) above; the measured number falls inside the stated range.
By their numbers in this assay, from the lowest: compounds 3 and 2 (each within the scatter of the next); then compound 1.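

In this assay, the 2-methoxyphenyl group on the aromatic nitrogen gives a 1.5-fold lower number from compound 2 to compound 3 (0.18 log units; within the scatter), so compound 2 and compound 3 cannot be told apart in this assay. Against 2,6-difluorophenyl the same exchange gives a 12-fold lower number from compound 1 to compound 3 (1.07 log units; beyond the scatter), which shows that, among these three compounds, a halogen on this aryl ring is not required for the lower numbers; compound 1 alone stands apart, although it too carries halogens. Nothing measured here explains why compound 1 differs from the other two.

Going by these compounds, how a plain phenyl or a 2-aminophenyl group would compare on the same nitrogen remains open. So does the effect of a carboxylic acid in place of the methyl ketone, since that part stays the same in all three compounds.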